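The compounds below may be only part of what the source reports. "The series", "measured", "known", "first", "only" and "open" are said of these compounds alone.

Compound 3, `N#CC1=C(N)Oc2c(c3nc4ccccc4nc3c3ccccc23)C12C(=O)N(Cc1cnnn1-c1ccc(N)cc1)c1ccccc12`, is one of three close relatives built on the same core. In a functional assay on MCF7 cells (Homo sapiens) for antiproliferative activity, read by MTT assay, with a stated time of 48 h (on this read-out lower numbers stand for stronger inhibition and higher numbers for weaker inhibition), compound 3 gives > 50000 nM, which is a limit of the assay rather than a measured number. Compound 1, `N#CC1=C(N)Oc2c(c3nc4ccccc4nc3c3ccccc23)C12C(=O)N(Cc1cnnn1-c1ccc(F)cc1)c1ccccc12`, carries a 4-fluorophenyl on the aromatic nitrogen; in this assay compound 1 gives > 50000 nM, again a limit. Compound 2, `COc1ccccc1-n1nncc1CN1C(=O)C2(C(C#N)=C(N)Oc3c2c2nc4ccccc4nc2c2ccccc32)c2ccccc21`, carries a 2-methoxyphenyl there; in this assay compound 2 gives > 50000 nM, also a limit. All three values sit at the limit of > 50000 nM in this assay, at which 3 of the 3 values shown sit, so the steps a step that the two limits leave unreadable from compound 1 to compound 2, a step that the two limits leave unreadable from compound 1 to compound 3 and a step that the two limits leave unreadable from compound 2 to compound 3 cannot be sized, and nothing can be said about which of the three is more or less active.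

Compound 4, `Cc1ccc(Cl)cc1-n1nncc1CN1C(=O)C2(C(C#N)=C(N)Oc3c2c2nc4ccccc4nc2c2ccccc32)c2ccccc21`, differs from compound 3 by 5-chloro-2-methylphenyl in place of 4-aminophenyl on an aromatic nitrogen. The three measured steps bear on this change only in that they all swapped the group on the same aromatic nitrogen, and none of them moved any compound away from the limit. For the measured compounds named here, no step of readable size is therefore available, and no shift beyond the scatter is expected in this assay: the estimated step that the limit leaves unreadable from compound 3 to compound 4 is expected to be near zero. The estimate for compound 4 in this assay is 60000 nM, expected to fall between 15000 nM and 250000 nM, most likely reported again as a limit.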

Compound 4, half-maximal inhibitory concentration: > 50000 nM
Compound 4 gave a limit, no number; the forecaster's own chance of this, stated with the estimate: 80%; the middle value does not contradict the limit.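

In this assay compound 4 also gives only a limit, so its steps from compound 1, compound 2 and compound 3 cannot be read: the limit of > 50000 nM in this assay, at which 4 of the 4 values shown sit.

The four compounds leave open whether any group on this aromatic nitrogen would give a measurable value on the shared core.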